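The source may hold more compounds than are shown below. What is called first, only, known or untested is meant among the compounds shown, and "the series" means these compounds.

In a functional assay on SW-620 cells (Homo sapiens) for inhibition, read by MTT assay, with a stated time of 72 h (a higher number here means a weaker inhibitor, a lower number a stronger inhibitor), three compounds have been measured.
Compound 1, `COc1cc(NC(C)CCCNC(=O)NNC(=O)Nc2ccc(F)cc2)c2ncccc2c1`, gives > 100000 nM, which is a limit of the assay and not a number.
Compound 2, `COc1cc(NC(C)CCCNC(=O)Nc2ccc(F)cc2)c2ncccc2c1`, gives 25000 nM.
Compound 3, `COc1cc(NC(C)CCCNC(=O)Nc2cccc(O)c2)c2ncccc2c1`, gives 27000 nM.

Compound 3 thus gives the highest of the two numbers, with compound 2 nearest: a 1.1-fold higher number from compound 2 to compound 3 (0.03 log units; within the scatter). Compound 4, `COc1cc(NC(C)CCCNC(=O)NNC(=O)Nc2ccc(O)cc2)c2ncccc2c1`, differs from compound 3 in that (((4-hydroxyphenyl)carbamoyl)amino in place of 3-hydroxyphenyl on an amide-type nitrogen). Going by the values given here, two measured steps bear on this change: an at least 4.0-fold lower number from compound 1 to compound 2 (0.60 log units; beyond the scatter) and an at least 3.7-fold lower number from compound 1 to compound 3 (0.56 log units; beyond the scatter); both remove the same kind of carbamoylamino link that compound 4 reintroduces, and both rest on the limit (the limit of > 100000 nM in this assay, at which 1 of the 3 values shown sits). Reinserting that link is therefore expected to raise the number in this assay, probably back to a limit. For compound 4 the estimated value is 100000 nM, within 40000 nM to 300000 nM. This corresponds to an expected step of a 3.7-fold higher number from compound 3 to compound 4 (0.57 log units; beyond the scatter).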

Compound 4, half-maximal inhibitory concentration: > 100000 nM
Compound 4: no number, only a limit (the forecaster's own chance of this, stated with the estimate: 60%); the middle value lies on the limit itself.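

In this assay, ((4-hydroxyphenyl)carbamoyl)amino on the amide-type nitrogen gives an at least 3.7-fold higher number from compound 3 to compound 4 (0.56 log units; beyond the scatter) and an at least 4.0-fold higher number from compound 2 to compound 4 (0.60 log units; beyond the scatter), so the rise seen earlier with the fluorinated compound also appears with a hydroxylated aromatic ring. Both compounds carrying this group now end at a limit, not a number: the limit of > 100000 nM in this assay, at which 2 of the 4 values shown sit. The step for hydroxy in place of fluoro on an aromatic carbon cannot be read.

Going by these compounds, it remains open whether the loss follows the carbamoylamino link itself or its length. On these data alone, it is also open whether an amine or a carboxylic acid on that aromatic ring would bring the number below the limit.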